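Swapping Trifluoromethoxy for Fluoro: a Solubility Outlook

The source may hold more compounds than are shown below. What is called first, only, known or untested is meant among the compounds shown, and "the series" means these compounds.

Three compounds built on a shared core have been examined in a physicochemical assay for solubility, in phosphate buffer, at pH 6.5; a higher number here means a more soluble compound, a lower number a less soluble compound. Compound 1 `CCOc1cc(CN2CCC(NC(=O)c3ccc(N)nc3)CC2)cc(OCC)c1-c1ccc(F)cc1` gives 123 ug/mL in this assay. Compound 2 `CCOc1cc(CN2CCC(NC(=O)c3cncc(C)c3)CC2)ccc1-c1ccc(F)cc1` gives 101 ug/mL. Compound 3 `CCOc1cc(CN2CCC(NC(=O)c3cncc(C)c3)CC2)cc(OCC)c1-c1ccc(OC(F)(F)F)cc1` returns only a limit rather than a number, < 1 ug/mL, and so stands at the limit of < 1 ug/mL in this assay, at which 1 of the 3 values shown sits.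

Compound 4 `CCOc1cc(CN2CCC(NC(=O)c3cncc(C)c3)CC2)cc(OCC)c1-c1ccc(F)cc1` has not yet been measured; it differs from compound 3 by fluoro in place of trifluoromethoxy on an aromatic carbon. For the measured compounds named here, no pair of measured compounds shows this single change, so its size is not read directly. Compound 1 and compound 2, which both carry the fluoro group, give the two numerical values in this assay. The step from compound 3 to compound 4 is expected to be upward and beyond the scatter, an at least 60-fold higher number from compound 3 to compound 4 (1.77 log units; beyond the scatter). Compound 4 is estimated at 60 ug/mL, between 15 ug/mL and 150 ug/mL.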

Compound 4, solubility: 94 ug/mL
Beside the measured number, compound 4's estimate is 1.6-fold (0.19 log units) below it; low and high end bracket the measured number.
By their numbers in this assay, from the lowest: compounds 4, 2 and 1 (each within the scatter of the next). At a limit, below all of these: compound 3.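

In this assay, the change from 4-(trifluoromethoxy)phenyl to 4-fluorophenyl can now be read directly on the shared core (an at least 94-fold higher number from compound 3 to compound 4 (1.97 log units; beyond the scatter)), and this step rests on a limit rather than a number: the limit of < 1 ug/mL in this assay, at which 1 of the 4 values shown sits. Among the fluoro compounds, neither other single change goes beyond the scatter: ethoxy in place of hydrogen on an aromatic carbon (a 1.1-fold lower number from compound 2 to compound 4 (0.03 log units; within the scatter)) and 5-methylpyridin-3-yl in place of 6-aminopyridin-3-yl on a carbonyl carbon (a 1.3-fold lower number from compound 1 to compound 4 (0.12 log units; within the scatter)).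

On these data alone, the true size of the step from trifluoromethoxy to fluoro remains open. So does how chloro, methoxy or a morpholine would read on this aromatic carbon.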